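This account rests on a few compounds, and the source may have more. Where it says the series, first, only, none or still open, it means among the compounds named here.

Measured compounds:
- compound 1, `NC(=O)c1c(NC(=O)c2ccccc2Cl)sc2c1CCN(C(=S)Nc1cccc3ccccc13)C2`: 20700 nM
- compound 2, `NC(=O)c1c(NC(=O)c2ccccc2Cl)sc2c1CCN(C(=S)Nc1ccccc1C(F)(F)F)C2`: 1870 nM
- compound 3, `CSc1ccccc1NC(=S)N1CCc2c(sc(NC(=O)c3ccccc3Cl)c2C(N)=O)C1`: 13800 nM

In a functional assay on MKN-74 cells (Homo sapiens) for antiproliferative activity, with a stated time of 24 h (a higher number here means a weaker inhibitor, a lower number a stronger inhibitor), compound 3 gives 13800 nM, the second highest of the three numbers. Its nearest neighbour is compound 1, and that gap, a 1.5-fold lower number from compound 1 to compound 3 (0.18 log units; within the scatter), is within the scatter; its furthest is compound 2, from which it is separated by a 7.4-fold higher number from compound 2 to compound 3 (0.87 log units; beyond the scatter), beyond the scatter.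

Compound 4, `NC(=O)c1c(NC(=O)c2ccccc2Cl)sc2c1CCN(C(=S)Nc1ccccc1-c1ccccc1)C2`, differs from compound 3 by phenyl in place of methylsulfanyl on an aromatic carbon. For the measured compounds named here, no measured step puts a phenyl in that position, so the bearing steps are indirect: a 7.4-fold higher number from compound 2 to compound 3 (0.87 log units; beyond the scatter) shows that exchanging the group on that aromatic carbon can move the number well beyond the scatter, while an 11-fold lower number from compound 1 to compound 2 (1.04 log units; beyond the scatter) and a 1.5-fold lower number from compound 1 to compound 3 (0.18 log units; within the scatter) show that replacing the whole aryl group gives either a large step or none. Going by the values given here, with no closer precedent, the estimate for compound 4 is kept near compound 3, as a step of a 1.2-fold lower number from compound 3 to compound 4 (0.06 log units; within the scatter) that is expected to stay within the scatter, but with a wide range. Compound 4 is therefore expected to give about 12000 nM in this assay, between 3000 nM and 45000 nM.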

Compound 4, half-maximal inhibitory concentration: 25800 nM
Beside the measured number, compound 4's estimate is 2.2-fold (0.33 log units) below it; low and high end bracket the measured number.
By their numbers in this assay, from the lowest: compound 2; then compounds 3, 1 and 4 (each within the scatter of the next).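

In this assay, the step of a 1.9-fold higher number from compound 3 to compound 4 (0.27 log units; within the scatter) shows that phenyl can stand in place of methylsulfanyl on this aromatic carbon, ortho to a large group, without leaving the scatter, even though it brings a whole aromatic ring. Trifluoromethyl now stands apart from two different groups at this position, as the large step of a 14-fold higher number from compound 2 to compound 4 (1.14 log units; beyond the scatter) adds to the earlier one, while the step of a 1.2-fold higher number from compound 1 to compound 4 (0.10 log units; within the scatter) leaves 2-phenylphenyl and naphthalen-1-yl indistinguishable. Nothing measured here explains why trifluoromethyl stands apart.

The compounds shown leave open whether the lower number belongs to trifluoromethyl alone or also appears with chlorine, a nitrile or methoxy on the same carbon. They also do not tell how an amine or a carboxylic acid would fare there.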